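The compounds below may be only part of what the source reports. "The series", "measured", "known", "first", "only" and "open" are said of these compounds alone.

In a toxicity assay on Huh-7.5 cells (Homo sapiens) for inhibition, read by MTT assay, with a stated time of 96 h (a lower number here means that less compound is tolerated, a higher number that more compound is tolerated), compound 3 `CC1CN(Cc2ccc(NC(=O)c3ccc(OCCCCl)c([N+](=O)[O-])c3)cc2C(F)(F)F)CC(C)O1` gives 2300 nM. Compound 1 `CN1CCN(Cc2ccc(NC(=O)c3ccc(OCCCCl)c(Cl)c3)cc2C(F)(F)F)CC1` gives 4100 nM, and these two values lie within the usual scatter of each other. Compound 2 `O=C(Nc1ccc(CN2CC(C(=O)O)C2)c(C(F)(F)F)c1)c1ccc(OCCCCl)c([N+](=O)[O-])c1` reaches only a limit of the assay, > 200000 nM. Placing 2,6-dimethylmorpholin-4-yl in the position of 3-carboxyazetidin-1-yl makes up the only measured step, an at least 86-fold lower number from compound 2 to compound 3 (1.93 log units; beyond the scatter), which is large but rests on that limit.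

Compound 4 `CN1CCN(Cc2ccc(NC(=O)c3ccc(OCCCCl)c([N+](=O)[O-])c3)cc2C(F)(F)F)CC1` differs from compound 3 as follows: 4-methylpiperazin-1-yl in place of 2,6-dimethylmorpholin-4-yl on a saturated chain carbon bound to an aromatic carbon. The large step bears on this change only loosely, as 3-carboxyazetidin-1-yl takes no part in it. The closer guide is compound 1, which also carries 4-methylpiperazin-1-yl and gives 4100 nM. No step beyond the scatter is therefore expected in this assay. The expected change is a 1.3-fold higher number from compound 3 to compound 4 (0.12 log units; within the scatter), a small one. For compound 4 the estimated value is 3000 nM, with an expected range from 1200 nM to 8000 nM.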

Compound 4, half-maximal cytotoxic concentration: 6800 nM
For compound 4 the middle estimate is 2.3-fold (0.36 log units) below the measured one; low and high end bracket the measured number.
By their numbers in this assay, from the lowest: compounds 3, 1 and 4 (each within the scatter of the next, the first and the last beyond it). At a limit, above all of these: compound 2.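

In this assay, the step of a 3.0-fold higher number from compound 3 to compound 4 (0.47 log units; beyond the scatter) shows that this position on a saturated chain carbon bound to an aromatic carbon responds modestly even when both rings carry no net charge, so the large carboxyazetidine steps are not its only effect. With 4-methylpiperazin-1-yl held fixed, nitro in place of chloro on an aromatic carbon gives a 1.7-fold higher number from compound 1 to compound 4 (0.22 log units; within the scatter), and this stays within the scatter. The change from 3-carboxyazetidin-1-yl gives an at least 29-fold lower number from compound 2 to compound 4 (1.46 log units; beyond the scatter), a large step that rests on the limit of compound 2: the limit of > 200000 nM in this assay, at which 1 of the 4 values shown sits.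

The compounds shown do not separate the ring oxygen and nitrogen from the methyl groups, which plain morpholin-4-yl or piperazin-1-yl could do. From the compounds shown here alone, it also remains open whether a carboxylic acid on a six-membered ring would behave like 3-carboxyazetidin-1-yl.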